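The source may report more compounds than this note shows. Statements on the series, on what has been measured and on what is new or still open speak of the compounds shown alone.

Compound 3, `O=C(NCCO)c1c(Cn2c(=O)n(C3CC3)c3ccncc32)nc2cc(Cl)ccn12`, is tested in an ADME assay on HEp-2 cells (Homo sapiens) for cytotoxicity, read by CCK-8 assay, with a stated time of 6 days; a lower number here means that less compound is tolerated, a higher number that more compound is tolerated. In this assay compound 3 gives > 100000 nM, which is a limit of the assay and not a measured number. The two other measured compounds stand at the same place: compound 1, `O=c1n(Cc2nc3cc(F)ccn3c2CCCCO)c2cnccc2n1C1CC1`, gives > 100000 nM, a limit, and compound 2, `O=c1n(Cc2nc3ccccn3c2CCCCO)c2cnccc2n1C1CC1`, gives > 100000 nM, again a limit. Going by the values given here, the one step between measured compounds, a step that the two limits leave unreadable from compound 1 to compound 2, is therefore unreadable, and all that can be said of the set is the limit of > 100000 nM in this assay, at which 3 of the 3 values shown sit.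

Compound 4, `CS(=O)(=O)c1ccc(-c2c(Cn3c(=O)n(C4CC4)c4ccncc43)nc3cc(Cl)ccn23)cc1`, has not yet been measured. It differs from compound 3 in one place: 4-(methylsulfonyl)phenyl in place of (2-hydroxyethyl)carbamoyl on an aromatic carbon. Among the compounds with values here, no measured step covers this kind of change, so there is no basis for expecting a move in either direction beyond the scatter; the estimate can only lean on the shared limit of the three measured compounds. Compound 4 is accordingly expected to give about 100000 nM in this assay, with a plausible range from 30000 nM to 300000 nM, which would mean an estimated step of a number no higher from compound 3 to compound 4 (the limit leaves the size open), and a limit rather than a number is the likelier outcome.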

Compound 4, half-maximal cytotoxic concentration: > 100000 nM
Compound 4 gave a limit, no number; the forecaster's own chance of this, stated with the estimate: 65%; the middle value sits exactly at the limit.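

The results for compound 3 and compound 4 are both limits of the assay and not numbers, so the step between them cannot be read. The compounds shown leave open at what concentration any of them would harm these cells, since all share one limit: the limit of > 100000 nM in this assay, at which 4 of the 4 values shown sit.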